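This account rests on a few compounds, and the source may have more. Where it says the series, first, only, none or still open, it means among the compounds named here.

Compound 1 `O=C(NCc1cccc(Cn2cnc3ccccc32)c1)c1cc(Br)c[nH]1` gives 16 nM in an assay for inhibition of Indoleamine 2,3-dioxygenase 1 (Homo sapiens), read by HPLC, with a stated time of 48 h; on this read-out lower numbers stand for stronger inhibition and higher numbers for weaker inhibition.
Compound 2 `O=C(NCc1cccc(Cn2cnc3ccccc32)c1)c1ccc(Br)cc1` gives 134 nM in this assay.
Compound 3 `O=C(NCc1cccc(Cn2cnc3ccccc32)c1)c1ccc(Cl)cc1` gives 477 nM in this assay.

Of the three measured compounds, compound 1 has the lowest number and so is the strongest inhibitor among them. Its nearest neighbour is compound 2, reached by a step of an 8.4-fold higher number from compound 1 to compound 2 (0.92 log units; beyond the scatter), and the furthest is compound 3, reached by a step of a 30-fold higher number from compound 1 to compound 3 (1.47 log units; beyond the scatter). Both of these steps alter the group attached to the carbonyl carbon. The third measured step, a 3.6-fold higher number from compound 2 to compound 3 (0.55 log units; beyond the scatter), exchanges one halogen for another on that same end of the molecule.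

Compound 4 `O=C(NCc1cccc(Cn2cnc3ccc(Br)cc32)c1)c1cc(Br)c[nH]1` keeps all of compound 1 and differs only by bromo in place of hydrogen on an aromatic carbon. Every measured step changes the amide side of the molecule, while the fused two-ring system stays the same throughout; the three measured compounds therefore give no direct guide to a change on that system. A single added bromine on an untouched ring is, in the absence of any measured step at that position, expected to produce a step from compound 1 to compound 4 that is small or within the scatter, in either direction, a 1.1-fold lower number from compound 1 to compound 4 (0.06 log units; within the scatter). Compound 4 is estimated to give 14 nM, with a range from 4 nM to 50 nM.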

Compound 4, half-maximal inhibitory concentration: 19 nM
For compound 4 the middle estimate is 1.4-fold (0.13 log units) below the measured one, and the stated range covers the measured number.
By their numbers in this assay, from the lowest: compounds 1 and 4 (each within the scatter of the next); then compound 2; then compound 3.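

On the six-membered aromatic ring of carbon only, part of the fused system of two rings, bromo in place of hydrogen gives a 1.2-fold higher number from compound 1 to compound 4 (0.07 log units; within the scatter) in this assay, so the numbers for the two compounds cannot be told apart. For the compounds shown here, this is the first measured step on that side of the molecule, since the earlier steps all changed the group on the carbonyl carbon and all lay beyond the scatter; here, a bromine atom enters at this aromatic carbon without a difference that this assay can resolve. Nothing available on these compounds explains this result.

Going by these compounds alone, this single step covers only one group at one carbon, so it remains open whether a methoxy group, an amine or a carboxylic acid at the same place would also give a number within the scatter of compound 1, and whether bromo at the other carbons of that ring would do so. As far as these compounds go, it also remains open whether the same bromo would behave alike in compound 2, which carries 4-bromophenyl on the carbonyl carbon.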